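The source may report more compounds than this note shows. Statements on the series, on what has been measured and on what is new or still open speak of the compounds shown alone.

Series notes: oxime ether acids carrying a chain ending in a carboxylic acid, read out in a functional assay on the whole organism for inhibition, with Rattus norvegicus as the target, with a stated time of 4 h, at a dose of 50 mg/kg by the intraperitoneal route; a lower number here means less inhibition, a higher number more inhibition at the dose given (going by the name of the read-out).

Compound 1, `C/C(=N\OCCC(=O)O)C1CCCCC1`, gives 0% in this assay. Compound 2, `O=C(O)CCO/N=C/C1CCCCC1`, differs from compound 1 in several places; in this assay compound 2 gives 0%. Compound 3, `C/C(=N\OCCC(=O)O)c1ccccc1`, gives 40% in this assay, the highest of the three numbers; its nearest neighbour by value is compound 1, lower by a gap beyond the scatter, and compound 2 stands at the same distance, also beyond the scatter. For the measured compounds named here, compound 3 differs from compound 1 in its ring rather than at the chain, and no single-change step links any two measured compounds.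

The next compound, compound 4, `CC/C(=N\OCCC(=O)O)c1ccccc1`, differs from compound 3 by methyl in place of hydrogen on a saturated chain carbon bound to a carbon with a double bond to nitrogen. The change keeps the acid chain and the core of compound 3 untouched and alters only the group on the carbon with a double bond to nitrogen. Nothing measured speaks to this position, so the step in this assay is expected to be small, none beyond the scatter, in either direction. Compound 4 is expected to give 40% in this assay, between 10% and 65%, a step from compound 3 of no change at the digits printed from compound 3 to compound 4 (within the scatter), because compound 3 gives 40% and the change is a single carbon at the chain.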

Compound 4, a percentage reported as inhibition, in the whole organism at one dose (the size of the read-out at that dose, not a potency): 28%
Estimate against measurement, compound 4: 12 percentage points above, and the stated range covers the measured number.
By their numbers in this assay, from the lowest: compounds 1 and 2 (each within the scatter of the next); then compound 4; then compound 3.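

The series now has its first single-change step: in this assay, methyl in place of hydrogen on a saturated chain carbon bound to a carbon with a double bond to nitrogen gives a number 12 percentage points lower from compound 3 to compound 4 (beyond the scatter). This position is therefore not silent, and even the change from methyl to ethyl registers in the read-out, though inhibition is reduced rather than lost, as compound 4 still gives 28%. No measurement at hand offers an explanation for this step.

As far as these compounds go, a single step at one dose and one time sets no trend at this position, so it remains open whether a longer chain such as propyl, a branched group such as isopropyl, or a polar group such as hydroxymethyl would lower the number further, hold it or restore it. From the compounds shown here alone, it also remains open whether the same change from methyl to ethyl would carry the same weight with a different group on the ring of compound 3, such as chlorine or methoxy, or with an amide in place of the carboxylic acid.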